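Replacing the vinyl of compound 3 with isopropyl

A few compounds are considered here, and "the series" means these few. Any claim that something is new, unique, unknown or untested is made for them only; others in the source may bear on it.

Measured compounds:
compound 1 `COc1ccc(CN(C(=O)CBr)c2cc(OC)c(OC)c(OC)c2)cc1O` — 68 nM
compound 2 `COc1ccc(CN(C(=O)/C=C/CBr)c2cc(OC)c(OC)c(OC)c2)cc1O` — 59 nM
compound 3 `C=CC(=O)N(Cc1ccc(OC)c(O)c1)c1cc(OC)c(OC)c(OC)c1` — 98 nM

In a functional assay on HCT-116 cells (Homo sapiens) for inhibition, read by MTT assay, with a stated time of 48 h (on this read-out higher numbers stand for weaker inhibition and lower numbers for stronger inhibition), compound 3 gives 98 nM. Compound 3 sits at the top of the three numbers, but a 1.4-fold higher number from compound 1 to compound 3 (0.16 log units; within the scatter) and a 1.7-fold higher number from compound 2 to compound 3 (0.22 log units; within the scatter) are both within the scatter, and so is a 1.2-fold lower number from compound 1 to compound 2 (0.06 log units; within the scatter), so the three compounds read as one level on this assay.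

Compound 4 `COc1ccc(CN(C(=O)C(C)C)c2cc(OC)c(OC)c(OC)c2)cc1O` differs from compound 3 by isopropyl in place of vinyl on a carbonyl carbon. Within the data shown here, the three measured steps all swap one group on the carbonyl carbon for another and all stay within the scatter, yet none of them brings in a group like isopropyl, so no measured step bears directly on this change. The expectation for compound 4 therefore rests on little: a number somewhat higher than that of compound 3 is expected, with a wide range, as a 4.1-fold higher number from compound 3 to compound 4 (0.61 log units; beyond the scatter) expresses. Compound 4 is thus estimated at 400 nM, between 80 nM and 4000 nM.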

Compound 4, half-maximal inhibitory concentration: 310 nM
Beside the measured number, compound 4's estimate is 1.3-fold (0.11 log units) above it, and the stated range covers the measured number.
By their numbers in this assay, from the lowest: compounds 2, 1 and 3 (each within the scatter of the next); then compound 4.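

In this assay, among these compounds, the place on the carbonyl carbon, which had read as one level across bromomethyl, 3-bromoprop-1-en-1-yl and vinyl, proves not to be indifferent to the group it carries: isopropyl gives a 3.2-fold higher number from compound 3 to compound 4 (0.50 log units; beyond the scatter) and is the first group here to leave that level. The other two steps, a 5.3-fold higher number from compound 2 to compound 4 (0.72 log units; beyond the scatter) and a 4.6-fold higher number from compound 1 to compound 4 (0.66 log units; beyond the scatter), agree, and the double bond alone does not sort the four, since bromomethyl in compound 1 has none either and compound 1 stays level with compound 3. Nothing shown gives a reason for this rise.

Going by these compounds, whether the rise belongs to isopropyl in particular stays open: ethyl or methyl on the same carbonyl carbon would show whether other groups without bromine or a double bond read like compound 4. On these data alone, how a longer chain or an amine would read at this place is equally open.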